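The compounds below may be only part of what the source reports. "The series", "measured", "known", "first", "only" and "open" are said of these compounds alone.

Working notes on the amide series. Among the measured compounds shown here, the shared core is the one seen in compound 2 `CC(=O)Nc1cccc2c(-c3cccc(NC(=O)c4ccc5c(c4)OCCO5)c3)ccnc12`, with the aryl group on the carbonyl carbon varied. In a functional assay on A375P cells (Homo sapiens) for antiproliferative activity, read by MTT assay, with a stated time of 48 h (on this read-out higher numbers stand for weaker inhibition and lower numbers for stronger inhibition), compound 2 gives 570 nM. Compound 1 `CC(=O)Nc1cccc2c(-c3cccc(NC(=O)c4ccc(Cl)cc4C(F)(F)F)c3)ccnc12` carries 4-chloro-2-(trifluoromethyl)phenyl at that position; in this assay compound 1 gives > 20000 nM, which is a limit of the assay and not a number. For the measured compounds named here, the only measured step is an at least 35-fold lower number from compound 1 to compound 2 (1.54 log units; beyond the scatter), and one end of it sits at the limit of > 20000 nM in this assay, at which 1 of the 2 values shown sits. Among the values shown, compound 2 holds the only number; the other value is a limit.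

Compound 3 `CC(=O)Nc1cccc2c(-c3cccc(NC(=O)c4cc(C)oc4C)c3)ccnc12` is the next change at the same place: 2,5-dimethylfuran-3-yl in place of 2,3-dihydro-1,4-benzodioxin-6-yl on a carbonyl carbon. Both the measured step and this one swap the aryl on the carbonyl carbon, so the measured step bears on it, though only as a rough guide: it was large, and it shows that this group can move the number far. The number for compound 3 in this assay is expected to come out higher than that of compound 2, by a moderate step. The expected step is a 2.6-fold higher number from compound 2 to compound 3 (0.42 log units; beyond the scatter). For compound 3 the estimate is 1500 nM, with a range from 400 nM to 8000 nM.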

Compound 3, half-maximal inhibitory concentration: > 20000 nM
Compound 3 gave a limit, no number (the forecaster's own chance of this, stated with the estimate: 15%); middle value at least 13-fold (1.12 log units) away from the limit.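

In this assay, the swap at the carbonyl carbon is an at least 35-fold higher number from compound 2 to compound 3 (1.54 log units; beyond the scatter), so a second aryl group, this time a five-membered aromatic ring with 1 hetero atom, also fails to keep what compound 2 shows. Compound 3 gives > 20000 nM, which is a limit of the assay and not a number. The earlier step could have reflected 4-chloro-2-(trifluoromethyl)phenyl alone, but now two quite different groups end at the same limit, and among the three compounds shown only the 2,3-dihydro-1,4-benzodioxin-6-yl of compound 2 gives a number: the limit of > 20000 nM in this assay, at which 2 of the 3 values shown sit.

The step from compound 1 to compound 3 cannot be read, as both of its ends are limits. Still open, from the compounds shown here alone, is whether the number of compound 2 rests on the six-membered non-aromatic ring with 2 hetero atoms or on the six-membered aromatic ring of carbon only that carries it, a question that an unsubstituted phenyl, a 4-methoxyphenyl or a 1,3-benzodioxol-5-yl on the carbonyl carbon would bear on.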